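Methylating the sulfonamide nitrogen of compound 1

The compounds below may be only part of what the source reports. "The series", "measured", "known", "first", "only" and "open" are said of these compounds alone.

Compound 1 `CC(C)S(=O)(=O)Nc1ccc(N(C)C(=O)c2ccccc2)cc1`: 0.1 mg/kg
Compound 2 `CC(C)S(=O)(=O)N(C)c1ccc(N(C)S(=O)(=O)c2ccc(F)cc2)cc1`: 0.01 mg/kg
Compound 3 `CC(C)S(=O)(=O)Nc1ccc(NC(=O)c2ccccc2)cc1`: 10 mg/kg

In a functional assay on the whole organism with Mus musculus as the target, with a stated time of 20 min (a higher number here means that more compound is needed for the effect, a lower number that less compound is needed), compound 1 stands second highest of the three numbers, with compound 2 giving the lowest value and compound 3 the highest. Among the measured compounds shown here, the single one-place step measured, a 100-fold higher number from compound 1 to compound 3 (2.00 log units; beyond the scatter), concerns the amide-type nitrogen, not the sulfonamide. Compound 4 `CC(C)S(=O)(=O)N(C)c1ccc(N(C)C(=O)c2ccccc2)cc1` arises from compound 1 by methyl in place of hydrogen on a sulfonamide nitrogen. For the measured compounds named here, no measured step covers this position directly; compound 2, which carries a methyl on its sulfonamide nitrogen among other differences, shows a lower value than compound 1, while the amide step shows how strongly a methyl on a nitrogen can shift this assay. A modest lowering is therefore expected, a 3.3-fold lower number from compound 1 to compound 4 (0.52 log units; beyond the scatter). Compound 4 is estimated at 0.03 mg/kg, between 0.003 mg/kg and 0.3 mg/kg.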

Compound 4, minimum effective dose: 0.01 mg/kg
Estimate against measurement, compound 4: 3.0-fold (0.48 log units) above; low and high end bracket the measured number.
By their numbers in this assay, from the lowest: compounds 2 and 4 (each within the scatter of the next); then compound 1; then compound 3.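

In this assay, the sulfonamide nitrogen proves to be a position where one added methyl has a measurable effect on its own (a 10-fold lower number from compound 1 to compound 4 (1.00 log units; beyond the scatter)), which compound 2 could not show, as it differs from compound 1 in more than one place. With the earlier step on the amide nitrogen (a 100-fold higher number from compound 1 to compound 3 (2.00 log units; beyond the scatter)), each nitrogen now has a one-place reading, and in both pairs the methyl compound has the lower number. Nothing measured here bears on why the methyl has this effect. The compounds shown leave open how an ethyl group or a longer chain on this sulfonamide nitrogen would read, and whether the step holds when the amide nitrogen carries hydrogen.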